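The source may report more compounds than this note shows. Statements on the series, on what has been measured and on what is new or still open speak of the compounds shown alone.

Measured so far:
compound 1, `O=C(/C(=C\c1ccc(Cl)cc1)S(=O)(=O)c1ccc(Br)cc1)c1ccc(Br)cc1`, gives 50000 nM in a functional assay on DU-145 cells (Homo sapiens) for inhibition, read by trypan blue exclusion, with a stated time of 96 h; a lower number here means a stronger inhibitor of growth, a higher number a weaker inhibitor of growth
compound 2, `CCOc1ccc(/C=C(\C(=O)c2ccc(Cl)cc2)S(=O)(=O)Cc2ccc(F)cc2)cc1OC`, gives 50000 nM in this assay

Compound 1 stands level with compound 2 at the digits shown; the two values lie within the usual scatter, so no order between them can be read. Compound 3, `O=C(/C(=C\c1ccc(Br)c([N+](=O)[O-])c1)S(=O)(=O)c1ccc(Br)cc1)c1ccc(Br)cc1`, differs from compound 1 in one place: 4-bromo-3-nitrophenyl in place of 4-chlorophenyl on a double-bonded chain carbon bound to a double-bonded chain carbon. Going by the values given here, no step between two measured compounds is available to show what such a change does, and both measured compounds sit at the same weak level. The expected step is therefore none beyond the scatter: no change at the digits printed from compound 1 to compound 3 (within the scatter). Compound 3 is expected to give about 50000 nM in this assay, within a range from 25000 nM to 100000 nM.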

Compound 3, concentration for 50% growth inhibition: 10000 nM
The estimate for compound 3 lay 5.0-fold (0.70 log units) above the measured number, and the stated range ends above it.
By their numbers in this assay, from the lowest: compound 3; then compounds 1 and 2 (each within the scatter of the next).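

In this assay, 4-bromo-3-nitrophenyl in place of 4-chlorophenyl on a double-bonded chain carbon bound to a double-bonded chain carbon gives a 5.0-fold lower number from compound 1 to compound 3 (0.70 log units; beyond the scatter). This shows that a change at this position can move the number, which the two level earlier compounds could not show. No measurement here explains why the number moves.

As far as these compounds go, the new group differs from the old in both its bromine and its nitro group, so which of them matters stays open. Also open, from the compounds shown here alone, is how an amine or a carboxylic acid would fare at this position.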